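The source may report more compounds than this note shows. Statements on the series, on what has been measured and on what is new or still open speak of the compounds shown alone.

Measured so far in an ADME assay (liver) for metabolic stability, with Liver microsome (Homo sapiens) as the target, using microsomes; on this read-out lower numbers stand for slow clearance and higher numbers for fast clearance:
- compound 1 `Cc1cnc(NC(=O)c2cc(Oc3cnc(C(=O)N(C)C)cn3)c3cc(C)oc3c2)cn1`: < 8.5 mL/min/kg
- compound 2 `Cc1cnc(NC(=O)c2cc(Oc3cnc(C(=O)N(C)C)nc3)c3cc(C)oc3c2)cn1`: < 8 mL/min/kg
- compound 3 `CCN(C)C(=O)c1cnc(Oc2cc(C(=O)Nc3cnc(C)cn3)cc3oc(C)cc23)cn1`: < 8 mL/min/kg

Each of these entries is a limit of the assay and not a number. Two limits occur in the series: the limit of < 8 mL/min/kg in this assay, at which 2 of the 3 values shown sit, and (the limit of < 8.5 mL/min/kg in this assay, at which 1 of the 3 values shown sits). Compound 3 stands at a limit, < 8 mL/min/kg, so no number for it is available, and no order can be read among the three compounds.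

The next compound is compound 4 `Cc1cnc(NC(=O)c2cc(Oc3cnc(C(=O)N4CCCC4)cn3)c3cc(C)oc3c2)cn1`. The change from compound 3 is pyrrolidin-1-yl in place of ethyl(methyl)amino on a carbonyl carbon. In words, pyrrolidin-1-yl comes in place of ethyl(methyl)amino on a carbonyl carbon, and the rest of the structure is the same.

For the measured compounds named here, only one measured step touches this part of the molecule: a step that the two limits leave unreadable from compound 1 to compound 3. Going by the values given here, that step gives no size to carry over, and no measured step covers the closing of a ring at this place. The expectation therefore rests on the three limits alone, and no shift beyond the scatter is expected. The expected step is a number no lower from compound 3 to compound 4 (the limit leaves the size open). A limit is again a likely result in this assay. For compound 4 the estimate is 8 mL/min/kg, with an expected range of 5 mL/min/kg to 14 mL/min/kg.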

Compound 4, clearance: < 8.1 mL/min/kg
Compound 4: only a limit was reported (the forecaster's own chance of this, stated with the estimate: 60%); the middle value is on the limit's open side.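

Compound 1, compound 3 and compound 4 are all reported as limits in this assay, so neither the step from compound 3 to compound 4 nor the step from compound 1 to compound 4 can be read. The compounds shown leave open whether dimethylamino, ethyl(methyl)amino and pyrrolidin-1-yl on a carbonyl carbon differ at all in this assay.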